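A saturated, hydrated tail in place of an unsaturated acid

This account rests on a few compounds, and the source may have more. Where it says the series, first, only, none or still open, it means among the compounds named here.

Measured so far:
compound 1, `COC1=C(OC)[C@H](OC(C)=O)[C@H](C/C=C(\C)CC/C=C(\C)C[C@H](O)/C=C(\C)C(=O)O)[C@@H](C)C1=O`: > 30000 nM
compound 2, `COC1=C(OC)[C@H](O)[C@H](C/C=C(\C)CC/C=C(\C)CCC=C(C)C)[C@@H](C)C1=O`: 5700 nM

Both compounds were tested in a functional assay on A549 cells (Homo sapiens) for inhibition, read by sulforhodamine B assay, with a stated time of 48 h; a higher number here means a weaker inhibitor of growth, a lower number a stronger inhibitor of growth. The value of compound 1 in this assay, > 30000 nM, is a limit of the assay and not a number; compound 1 sits at the limit of > 30000 nM in this assay, at which 1 of the 2 values shown sits. Compound 2 carries a free hydroxyl and an unsubstituted hydrocarbon tail in place of the acetate and the acid-bearing tail of compound 1. In this assay compound 2 gives 5700 nM. Among the measured compounds shown here, no step between these two is computed here; the two values simply show that compound 2 gives a number while compound 1 gives only a limit.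

The step followed here leads to compound 3, `COC1=C(OC)[C@H](OC(C)=O)[C@H](C/C=C(\C)CC/C=C(\C)C[C@H](O)C[C@@H](C)C(O)O)[C@@H](C)C1=O`, which is not yet measured. Compound 3 differs from compound 1 by a group of 6 heavy atoms (4 carbon, 2 oxygen; no ring) in place of a group of 6 heavy atoms (4 carbon, 2 oxygen; no ring), on a saturated chain carbon bound to an oxygen on a saturated carbon and a saturated chain carbon. Because compound 1 stands at the limit of > 30000 nM in this assay, at which 1 of the 2 values shown sits, the most that can be said is that compound 3 is expected to stay near that limit, with no step beyond the scatter: the estimated step is a step that the limit leaves unreadable from compound 1 to compound 3. Compound 3 is therefore expected to give about 40000 nM, within 15000 nM to 120000 nM, and most likely the assay will again report only a limit.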

Compound 3, concentration for 50% growth inhibition: 15400 nM
Estimate against measurement, compound 3: 2.6-fold (0.41 log units) above; measured number inside the range.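

In this assay, compound 3 gives 15400 nM, so this change on the tail yields a measured number, which neither the opening comparison nor compound 1 alone could supply. On these data alone, compound 1 gives > 30000 nM, which is a limit of the assay and not a number, so the comparison has only one firm end: the limit of > 30000 nM in this assay, at which 1 of the 3 values shown sits. Placing the new group, which has no common name, where the 2-carboxyprop-1-en-1-yl group stood, on a saturated chain carbon bound to an oxygen on a saturated carbon and a saturated chain carbon, gives an at least 1.9-fold lower number from compound 1 to compound 3 (0.28 log units; that floor lies within the scatter), so the true size of the step stays unknown and its floor alone does not establish a real gain.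

The new group differs from the old one in several ways at once, since it loses both double bonds and gains a defined stereocentre, and the compounds shown cannot tell which of these differences matters. Also open, as far as these compounds go, is how a saturated chain ending in a carboxylic acid, or in an amine, would behave at this same place on the core of compound 1.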